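Replacing the Nitro Group: Expected Inhibition of Compound 4

The compounds below may be only part of what the source reports. "The series", "measured", "known", "first", "only" and "open" are said of these compounds alone.

Compound 2 `O=[N+]([O-])c1cccc(CNc2cc(C(F)(F)F)cc3[nH]ncc23)c1` is assessed in an assay for inhibition of Indoleamine 2,3-dioxygenase 1 (Homo sapiens), with stated times of 10 min and 60 min, tested at 100 uM (a lower number here means a weaker effect, a higher number a stronger effect of the compound at the concentration tested), where compound 2 gives 69%. Among the three measured compounds this is the second highest number: compound 1 `O=[N+]([O-])c1cccc(CNc2cc(Br)cc3[nH]ncc23)c1` gives 95%, while compound 3 `O=[N+]([O-])c1cc(Br)c(F)cc1CNc1cc(C(F)(F)F)cc2[nH]ncc12` gives 64%, a number within the scatter of compound 2. Within the data shown here, the only single-place step recorded, a number 26 percentage points lower from compound 1 to compound 2 (beyond the scatter), concerns trifluoromethyl in place of bromo on the shared core and not the group that now changes. Compound 4 `OC1CCCC(Nc2cccc(CNc3cc(C(F)(F)F)cc4[nH]ncc34)c2)C1` differs from compound 2 by (3-hydroxycyclohexyl)amino in place of nitro on an aromatic carbon. Among the measured compounds shown here, no measured step touches the nitro group, so the direction of this change is uncertain and the expected step is wide. Compound 4 is therefore estimated at 50%, ranging from 15% to 85%, which means an expected step of a number 19 percentage points lower from compound 2 to compound 4 (beyond the scatter).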

Compound 4, a percentage reported as inhibition, at one concentration (the size of the read-out at that concentration, not a potency): 2%
Estimate against measurement, compound 4: 48 percentage points above; the whole stated range lies above it.
By their numbers in this assay, from the lowest: compound 4; then compounds 3 and 2 (each within the scatter of the next); then compound 1.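

Among these compounds, putting (3-hydroxycyclohexyl)amino in place of nitro gives a number 67 percentage points lower from compound 2 to compound 4 (beyond the scatter) in this assay, the first view of a change at this position. The position therefore does not accept every group: with the rest of compound 2 kept, this single swap leaves compound 4 at 2%. The swap brings in a non-aromatic ring, a hydroxyl and an amine hydrogen together, so these parts cannot be told apart here. No measurement shown explains the fall. Going by these compounds, whether a plain amine or a carboxylic acid at this place would keep the inhibition stays open.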